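The source may hold more compounds than are shown below. What is called first, only, known or untested is meant among the compounds shown, and "the series" means these compounds.

Measured compounds:
compound 1 `CCCCOC(=O)Nc1ccc([Se]C#N)cc1` – in an ADME assay on BEAS-2B cells (Homo sapiens) for cytotoxicity, read by MTT assay, with a stated time of 72 h (a lower number here means a stronger inhibitor of growth, a higher number a weaker inhibitor of growth), compound 1 gives 5000 nM
compound 2 `CC(C)COC(=O)Nc1ccc([Se]C#N)cc1` – compound 2 gives 26900 nM
compound 3 `CCCCCCOC(=O)Nc1ccc([Se][Se]c2ccc(NC(=O)OCCCCCC)cc2)cc1` – compound 3 gives 10 nM

Compound 2 gives the highest number of the three, with compound 1 nearest and compound 3 far lower. The change to compound 4 `CCCCCCOC(=O)Nc1ccc([Se]C#N)cc1` is pentyl in place of isopropyl on a saturated chain carbon bound to an oxygen next to a carbonyl group. For the measured compounds named here, the one step that bears on it runs the other way: a 5.4-fold higher number from compound 1 to compound 2 (0.73 log units; beyond the scatter). Compound 4 undoes that branching and also lengthens the chain; compound 3 carries the same hexyl carbamate but differs elsewhere too, so its value shows only that a hexyl chain is compatible with a low number. A lower number than compound 2 is therefore expected, roughly reversing the step seen, as a 7.7-fold lower number from compound 2 to compound 4 (0.89 log units; beyond the scatter). Compound 4 is estimated at 3500 nM, within 700 nM to 17000 nM.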

Compound 4, concentration for 50% growth inhibition: 2800 nM
Beside the measured number, compound 4's estimate is 1.3-fold (0.10 log units) above it; the range from low to high includes it.
By their numbers in this assay, from the lowest: compound 3; then compounds 4 and 1 (each within the scatter of the next); then compound 2.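

In this assay, replacing the branched chain with the longer straight one gives a 9.6-fold lower number from compound 2 to compound 4 (0.98 log units; beyond the scatter) at this position, so chain shape and length are not interchangeable here. The two straight chains give a 1.8-fold lower number from compound 1 to compound 4 (0.25 log units; within the scatter) with no separation of butyl from hexyl, leaving only the branched compound 2 apart from compound 1 and compound 4. No measurement here explains this difference. On these data alone, whether a longer chain such as octyl keeps the number of compound 4 remains open, as does the effect of an amine or a carboxylic acid at the chain end.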